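The source may report more compounds than this note shows. Statements on the series, on what has been measured and on what is new or still open speak of the compounds shown alone.

In an assay on Sf21 cells for inhibition of high affinity nerve growth factor receptor (Homo sapiens), read by HTRF, with a stated time of 30 min, in the presence of a further agent that is not named here (a higher number here means a weaker inhibitor, a lower number a stronger inhibitor), the three measured compounds gave:

Compound 1 `CC1(C)c2[nH]nc(NC(=O)c3ccccc3)c2CN1Cc1cccc(I)c1`: 1360 nM
Compound 2 `Cc1ccc(CN2Cc3c(NC(=O)c4ccccc4)n[nH]c3C2(C)C)cc1F`: 940 nM
Compound 3 `Cc1ccc(F)c(CN2Cc3c(NC(=O)c4ccccc4)n[nH]c3C2(C)C)c1`: 880 nM

All three share one core and differ only in the aromatic group carried on the saturated chain carbon bound to the amine nitrogen in the ring. Compound 3 has the lowest number of the three, but the step of a 1.1-fold lower number from compound 2 to compound 3 (0.03 log units; within the scatter) and the step of a 1.5-fold lower number from compound 1 to compound 3 (0.19 log units; within the scatter) both lie within the scatter, so the three compounds cannot be separated by these numbers.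

Compound 4 `CC1(C)c2[nH]nc(NC(=O)c3ccccc3)c2CN1Cc1cc(F)c(F)c(F)c1` is the next variation at the same position: 3,4,5-trifluorophenyl in place of 2-fluoro-5-methylphenyl on a saturated chain carbon bound to an amine nitrogen in a ring. The measured steps that bear on this change are the three exchanges of the aromatic group already seen, a 1.4-fold lower number from compound 1 to compound 2 (0.16 log units; within the scatter), a 1.5-fold lower number from compound 1 to compound 3 (0.19 log units; within the scatter) and a 1.1-fold lower number from compound 2 to compound 3 (0.03 log units; within the scatter). Each of them swapped one substituted phenyl for another at this position, and none moved the number beyond the scatter. For the measured compounds named here, a fourth substituted phenyl at the same place is therefore expected to behave alike, with no step in this assay beyond the scatter in either direction.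

Compound 4 is expected to give about 950 nM in this assay, with a range from 420 nM to 2100 nM. The expected step is a 1.1-fold higher number from compound 3 to compound 4 (0.03 log units; within the scatter).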

Compound 4, half-maximal inhibitory concentration: 6960 nM
Compound 4: the middle estimate sits 7.3-fold (0.86 log units) below what was measured; measured number above the stated range.
By their numbers in this assay, from the lowest: compounds 3, 2 and 1 (each within the scatter of the next); then compound 4.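

In this assay, for the compounds shown here, this position turns out not to accept every substituted phenyl alike: 3,4,5-trifluorophenyl is the first group here to move the number beyond the scatter, making compound 4 the weakest inhibitor of the four (a 7.9-fold higher number from compound 3 to compound 4 (0.90 log units; beyond the scatter); a 7.4-fold higher number from compound 2 to compound 4 (0.87 log units; beyond the scatter); a 5.1-fold higher number from compound 1 to compound 4 (0.71 log units; beyond the scatter)). Losing the methyl group cannot be the whole story, since compound 1 also lacks a methyl on its phenyl, carrying iodine instead, and it stays within the scatter of compound 2 and compound 3. Nothing measured here explains why this group behaves differently.

Going by these compounds alone, with only one trifluorinated compound, the numbers cannot separate the effect of having three fluorines from that of where they stand on the phenyl. As far as these compounds go, it also remains open whether a plain phenyl, a phenyl with a single fluorine, or a phenyl bearing a methoxy group or an amine would stay with compounds 1 to 3 or fall with compound 4.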